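The source may report more compounds than this note shows. Statements on the series, on what has been measured and on what is new or still open speak of the compounds shown alone.

Of the compounds shown here, three have been tested in a functional assay (Homo sapiens) for inhibition of Nucleic Acid, tested at 100 uM; on this read-out lower numbers stand for less inhibition and higher numbers for more inhibition at the one concentration tested (going by the name of the read-out). Compound 1 `[O-][n+]1ccc2c(c1)ncn2C1O[C@H](CO)[C@@H](O)[C@H]1O` gives 5%, compound 3 `OC[C@H]1OC(n2cnc3c(S)nccc32)[C@H](O)[C@@H]1O` gives 6%, and compound 2 `CNc1[nH]ccc2ncnc1-2` gives 18%. Compound 2 stands highest of the three, its number lying beyond the scatter above both compound 3 and compound 1, though all three numbers are modest for this assay at the single concentration used. Compound 4 `CCNc1[nH]ccc2ncnc1-2` is the one not yet measured; it differs from compound 2 by methyl in place of hydrogen on a saturated chain carbon bound to a nitrogen on an aromatic ring. Going by the values given here, no step between measured compounds shows what methyl in place of hydrogen at such a position does here. With only one heavy atom entering and nothing else changed, the step from compound 2 to compound 4 is expected to be small, no change at the digits printed from compound 2 to compound 4 (within the scatter), with no clear direction beyond the scatter. Compound 4 is therefore estimated at 18%, within 5% to 35%.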

Compound 4, a percentage reported as inhibition, at one concentration (the size of the read-out at that concentration, not a potency): 3%
Estimate against measurement, compound 4: 15 percentage points above; measured number outside the range, below it.
By their numbers in this assay, from the lowest: compounds 4, 1 and 3 (each within the scatter of the next); then compound 2.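

In this assay, the change from methylamino to ethylamino is not a silent one: methyl in place of hydrogen on a saturated chain carbon bound to a nitrogen on an aromatic ring gives a number 15 percentage points lower from compound 2 to compound 4 (beyond the scatter). This position therefore responds to the entry of a single carbon, and the two groups are not interchangeable here. No measurement on hand accounts for this step.

What the compounds shown leave open is how an unsubstituted amine or a longer chain such as propylamino would read at this position. They also leave open whether a hydroxyethylamino group would keep the number of compound 2.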